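This account rests on a few compounds, and the source may have more. Where it says the series, first, only, none or still open, it means among the compounds named here.

Compound 1 `Cc1nn(-c2ncnc3nc[nH]c23)c2c1C(OCc1ccc(Cl)cc1Cl)CC(=O)N2` — 4 nM
Compound 2 `Cc1nn(-c2ncnc3nc[nH]c23)c2c1C(OC1CCCC1)CC(=O)N2` — 2 nM
Compound 3 `Cc1noc(C)c1COC1CC(=O)Nc2c1c(C)nn2-c1ncnc2nc[nH]c12` — 5 nM

All three compounds share the same core and were tested in a functional assay on HEK293 cells for agonist activity at G-protein coupled receptor 39 (Homo sapiens), read by scintillation proximity assay and inositol phosphate accumulation, with a stated time of 75 min, in the presence of a further agent that is not named here; on this read-out lower numbers stand for an effect already at smaller amounts and higher numbers for an effect only at larger amounts of compound. Compound 3 gives the highest of the three numbers: the step of a 1.3-fold higher number from compound 1 to compound 3 (0.10 log units; within the scatter) stays within the scatter, while the step of a 2.5-fold higher number from compound 2 to compound 3 (0.40 log units; beyond the scatter) lies beyond it. Compound 4 `Cc1nn(-c2ncnc3nc[nH]c23)c2c1C(OCCn1nccc1C)CC(=O)N2` has not been measured. It differs from compound 3 in one place: (5-methyl-1H-pyrazol-1-yl)methyl in place of 3,5-dimethyl-1,2-oxazol-4-yl on a saturated chain carbon bound to an oxygen on a saturated carbon.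

For the measured compounds named here, two measured steps bear on this change. The step of a 1.3-fold higher number from compound 1 to compound 3 (0.10 log units; within the scatter) exchanges one aromatic ring for another on the same saturated chain carbon and produces no difference beyond the scatter; the step of a 2.0-fold lower number from compound 1 to compound 2 (0.30 log units; within the scatter) replaces the whole group on the oxygen and likewise stays within the scatter. Only a 2.5-fold higher number from compound 2 to compound 3 (0.40 log units; beyond the scatter) reaches a modest size. A change of one five-membered aromatic ring for another is therefore expected to leave the number about where compound 3 stands, with the step of a 1.3-fold lower number from compound 3 to compound 4 (0.10 log units; within the scatter) expected to fall within the scatter. Compound 4 is estimated at 4 nM, with a range from 1.5 nM to 12 nM.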

Compound 4, half-maximal effective concentration: 10 nM
Compound 4: the middle estimate sits 2.5-fold (0.40 log units) below what was measured; low and high end bracket the measured number.
By their numbers in this assay, from the lowest: compounds 2, 1, 3 and 4 (each within the scatter of the next, the first and the last beyond it).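

Exchanging 3,5-dimethyl-1,2-oxazol-4-yl for (5-methyl-1H-pyrazol-1-yl)methyl keeps the heavy-atom count and the type of ring, and it gives a 2.0-fold higher number from compound 3 to compound 4 (0.30 log units; within the scatter), so this single change does not clearly separate the two compounds. Even so, compound 4 is the first compound to differ beyond the scatter from both other compounds, with a 2.5-fold higher number from compound 1 to compound 4 (0.40 log units; beyond the scatter) and a 5.0-fold higher number from compound 2 to compound 4 (0.70 log units; beyond the scatter), showing that the group at this position can shift the number further than the earlier compounds showed. Nothing available here explains this difference.

All the groups shown on this oxygen are uncharged and contain a carbon or aromatic ring, so the effect of an amine, a carboxylic acid or a longer chain remains open. Going by these compounds, it also remains open whether the methyl on the pyrazole ring matters, since no unsubstituted pyrazole appears for comparison.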